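Chloro for trifluoromethyl on the urea aryl of compound 3

The compounds below may be only part of what the source reports. "The series", "measured", "known", "first", "only" and "open" are said of these compounds alone.

Compound 3 `COc1cc(Cl)cc(-c2nn(-c3cccc(NC(=O)Nc4ccc(Cl)c(C(F)(F)F)c4)c3)cc2-c2ccncc2)c1` was tested in a functional assay on SK-MEL-5 cells (Homo sapiens) for inhibition, read by sulforhodamine B assay, with a stated time of 48 h, tested at 0.1 uM (a lower number here means a stronger effect, a higher number a weaker effect of the compound at the concentration tested), and gives 98%. Compound 1 `O=C(Nc1cccc(-n2cc(-c3ccncc3)c(-c3cc(O)cc(Cl)c3)n2)c1)Nc1ccc(Cl)c(C(F)(F)F)c1` gives 98% in this assay, so compound 3 stands level with it at the digits printed, no change at the digits printed from compound 1 to compound 3 (within the scatter), and the two are together the highest of the three numbers. Compound 2 `O=C(Nc1cccc(-n2cc(-c3ccncc3)c(-c3cc(O)cc(Cl)c3)n2)c1)Nc1ccc(Cl)c(Cl)c1` gives 92% in this assay, a number 6 percentage points lower from compound 1 to compound 2 (within the scatter). Compound 4 `COc1cc(Cl)cc(-c2nn(-c3cccc(NC(=O)Nc4ccc(Cl)c(Cl)c4)c3)cc2-c2ccncc2)c1` is not yet measured in this assay. It differs from compound 3 by chloro in place of trifluoromethyl on an aromatic carbon. Among the compounds with values here, the one measured step bearing on this is a number 6 percentage points lower from compound 1 to compound 2 (within the scatter), the same exchange on the same ring. A step of that size is therefore expected, a number 5 percentage points lower from compound 3 to compound 4 (within the scatter), not beyond the scatter. Compound 4 is estimated to give 93% in this assay, between 84% and 100%.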

Compound 4, a percentage reported as activity, at one concentration (the size of the read-out at that concentration, not a potency): 96%
The estimate for compound 4 lay 3 percentage points below the measured number; the range from low to high includes it.
By their numbers in this assay, from the lowest: compounds 2, 4, 1 and 3 (each within the scatter of the next).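

In this assay the exchange of trifluoromethyl for chloro now has a reading on a second core (a number 2 percentage points lower from compound 3 to compound 4 (within the scatter)), and the two readings agree: the same change on two cores in this assay, a number 6 percentage points lower (within the scatter) from compound 1 to compound 2 and a number 2 percentage points lower (within the scatter) from compound 3 to compound 4, 4 percentage points apart, within the scatter of two such steps

Methyl in place of hydrogen on the oxygen now also reads with 3,4-dichlorophenyl on the urea (a number 4 percentage points higher from compound 2 to compound 4 (within the scatter)), and again the two readings agree: the same change on two cores in this assay, no change at the digits printed (within the scatter) from compound 1 to compound 3 and a number 4 percentage points higher (within the scatter) from compound 2 to compound 4, 4 percentage points apart, within the scatter of two such steps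

Across these four compounds, neither change shows any dependence on the other in this assay at this one concentration.

On these data alone, whether a methyl, a nitrile or an amine in place of the trifluoromethyl would read the same stays open. Also open, as far as these compounds go, is whether the four compounds would separate at other concentrations.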